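Cyano to Methoxy on the Aryl Amide: Toxicity Outlook

The source may report more compounds than this note shows. Statements on the series, on what has been measured and on what is new or still open speak of the compounds shown alone.

Compound 2 `COc1ccc(-c2cnc(NC(=O)c3cccc(C#N)c3)n2C)cc1` was tested in a toxicity assay on THP-1 cells (Homo sapiens) for inhibition; on this read-out lower numbers stand for higher toxicity in this test and higher numbers for lower toxicity in this test. In this assay compound 2 gives > 100000 nM, which is a limit of the assay rather than a number. Compound 1 `COc1ccc(-c2cnc(NC(=O)c3ncc[nH]3)n2C)cc1` in this assay gives > 100000 nM, likewise a limit. The step that the two limits leave unreadable from compound 1 to compound 2 therefore has no readable size. Compound 3 `COc1ccc(-c2cnc(NC(=O)c3cccc(OC)c3)n2C)cc1` differs from compound 2 by methoxy in place of cyano on an aromatic carbon. Among the measured compounds shown here, both measured values sit at the limit of > 100000 nM in this assay, at which 2 of the 2 values shown sit, so no measured step offers a size to lean on. The expected step is a step that the limit leaves unreadable from compound 2 to compound 3, none beyond the scatter. Compound 3 is estimated at 150000 nM, between 50000 nM and 500000 nM, most likely again reported only as a limit.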

Compound 3, half-maximal cytotoxic concentration: > 100000 nM
Compound 3: a limit, no number; the forecaster's own chance of this, stated with the estimate: 85%; the middle value is on the limit's open side.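

No step can be read between compound 1, compound 2 and compound 3, since each value is a limit and not a number: the limit of > 100000 nM in this assay, at which 3 of the 3 values shown sit.

On these data alone, whether these compounds differ at all in this assay stays open.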